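Carbamate on the shared core: from compound 3 to compound 4

A few compounds are considered here, and "the series" means these few. Any claim that something is new, unique, unknown or untested is made for them only; others in the source may bear on it.

Measured so far in a functional assay on PANC-1 cells (Homo sapiens) for inhibition, read by MTT assay, with a stated time of 24 h, tested at 10 uM; a higher number here means more inhibition at the concentration tested (going by the name of the read-out), a lower number less inhibition:
compound 1 `CC(C)=CCC1Cc2c(O)cc(=O)n(CCCO)c2CC1(C)C` gives 25.6%;
compound 2 `CC(C)=CCC1Cc2c(OCCCNC(=O)c3ccco3)cc(=O)n(CCCO)c2CC1(C)C` gives 2.1%;
compound 3 `COc1ccccc1NC(=O)Oc1cc(=O)n(CCCO)c2c1CC(CC=C(C)C)C(C)(C)C2` gives 71.1%.

Compound 3 holds the highest of the three numbers in this assay: the nearest is compound 1, and the step of a number 45.5 percentage points higher from compound 1 to compound 3 (beyond the scatter) is large; the furthest is compound 2, and the step of a number 69 percentage points higher from compound 2 to compound 3 (beyond the scatter) is large as well. The step of a number 23.5 percentage points lower from compound 1 to compound 2 (beyond the scatter) is modest and runs the other way.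

The next structure, compound 4 `CC(C)=CCC1Cc2c(OC(=O)Nc3cccc(F)c3)cc(=O)n(CCCO)c2CC1(C)C`, keeps the carbamoyl on the oxygen of the ring that compound 3 carries and differs only in the aryl group on its amide-type nitrogen: 3-fluorophenyl in place of 2-methoxyphenyl on an amide-type nitrogen. For the measured compounds named here, no measured step changes that aryl group; the known steps concern only whether a carbamoyl is present on that oxygen. The account therefore expects compound 4 to stay near compound 3, with a step of a number 11.1 percentage points lower from compound 3 to compound 4 (beyond the scatter) of uncertain direction and not clearly beyond the scatter. Compound 4 is estimated at 60%, in a range from 35% to 85%.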

Compound 4, a percentage reported as inhibition, at one concentration (the size of the read-out at that concentration, not a potency): 66.1%
Estimate against measurement, compound 4: 6.1 percentage points below, within the range that was stated.
By their numbers in this assay, from the lowest: compound 2; then compound 1; then compounds 4 and 3 (each within the scatter of the next).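

In this assay, for the compounds shown here, the first change to the aryl group on the amide-type nitrogen gives a number 5 percentage points lower from compound 3 to compound 4 (within the scatter), so with 3-fluorophenyl in place of 2-methoxyphenyl the number stays level. The high number therefore does not depend on 2-methoxyphenyl alone: the carbamoyl on the oxygen of the ring again stands well clear of the hydrogen, with a number 40.5 percentage points higher from compound 1 to compound 4 (beyond the scatter), and of the 3-(((furan-2-yl)carbonyl)amino)propyl group, with a number 64 percentage points higher from compound 2 to compound 4 (beyond the scatter). No measurement available here explains why the two aryl groups read alike.

Because the swap removes the methoxy group and adds the fluorine in one step, the two changes cannot be told apart. Going by these compounds, it also remains open how a plain phenyl, a cyclohexyl group or a phenyl bearing a carboxylic acid would read on that nitrogen.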